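From 4-nitrophenyl to 3-nitrophenyl at a limit

A few compounds are considered here, and "the series" means these few. Any claim that something is new, unique, unknown or untested is made for them only; others in the source may bear on it.

Compound 1 `Nc1ccccc1NC(=O)CCCCCCc1nc(-c2ccccc2Cl)no1`: 8310 nM
Compound 2 `Nc1ccccc1NC(=O)CCCCCCc1nc(-c2ccc([N+](=O)[O-])cc2)no1`: > 100000 nM

Both values come from a functional assay on NCI-H661 cells (Homo sapiens) for antiproliferative activity, read by MTT assay, with a stated time of 72 h; a lower number here means a stronger inhibitor, a higher number a weaker inhibitor. As far as these compounds go, the entry for compound 2 is a limit, not a number, so its true position is unknown. Compound 3 `Nc1ccccc1NC(=O)CCCCCCc1nc(-c2cccc([N+](=O)[O-])c2)no1` differs from compound 2 in one change: 3-nitrophenyl in place of 4-nitrophenyl on an aromatic carbon. For the measured compounds named here, only one measured step bears on this, the large at least 12-fold higher number from compound 1 to compound 2 (1.08 log units; beyond the scatter), which exchanges the same substituent. A moderate step to a lower number is therefore expected in this assay, though with wide uncertainty. Compound 3 is estimated at 35000 nM, with an expected range of 8000 nM to 100000 nM. The expected change is an at least 2.8-fold lower number from compound 2 to compound 3 (0.45 log units; beyond the scatter).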

Compound 3, half-maximal inhibitory concentration: 7290 nM
Beside the measured number, compound 3's estimate is 4.8-fold (0.68 log units) above it; measured number below the stated range.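

In this assay, 3-nitrophenyl in place of 4-nitrophenyl gives an at least 13-fold lower number from compound 2 to compound 3 (1.13 log units; beyond the scatter), so at this position the outcome depends on where the nitro group sits on the phenyl ring, not merely on its presence. The entry for compound 2 is only a limit: the limit of > 100000 nM in this assay, at which 1 of the 3 values shown sits. The exchange of 2-chlorophenyl for 3-nitrophenyl gives a 1.1-fold lower number from compound 1 to compound 3 (0.06 log units; within the scatter), which leaves those two groups level. Still open, as far as these compounds go, is how 2-nitrophenyl, 3-aminophenyl or 3-methoxyphenyl would read at this position. From the compounds shown here alone, whether a shorter chain would preserve this level also remains open.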